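Two limits, and a rearranged ring group still unmeasured

This account rests on a few compounds, and the source may have more. Where it says the series, first, only, none or still open, it means among the compounds named here.

Measured so far in a functional assay on cells (Mast cell, Rattus norvegicus, strain Wistar) for activation, read by fluorescence, with a stated time of 15 min; on this read-out lower numbers stand for an effect already at smaller amounts and higher numbers for an effect only at larger amounts of compound:
Compound 1 `CCCCCCCCCCCCCCCCCC(=O)OC[C@@H](O)COP(=O)(O)OC[C@H](N)C(=O)OC`: > 10000 nM (a limit)
Compound 2 `CCCCCCCCCCCCCCCCCC(=O)OC[C@@H](O)COP(=O)(O)O[C@@H]1CCN[C@H]1C(=O)O`: > 10000 nM (a limit)

Compound 2 gives no number in this assay, only > 10000 nM, which is a limit. Neither measured compound has a number, as the limit of > 10000 nM in this assay, at which 2 of the 2 values shown sit, shows.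

Compound 3 `CCCCCCCCCCCCCCCCCC(=O)OC[C@@H](O)COP(=O)(O)O[C@@H]1CN[C@@H](C(=O)O)C1` has the same atoms as compound 2, joined differently: a group of 8 heavy atoms (5 carbon, 1 nitrogen, 2 oxygen; one five-membered non-aromatic ring with 1 hetero atom) in place of a group of 8 heavy atoms (5 carbon, 1 nitrogen, 2 oxygen; one five-membered non-aromatic ring with 1 hetero atom), on an oxygen.

For the measured compounds named here, only one measured step bears on this change, a step that the two limits leave unreadable from compound 1 to compound 2. It has no readable size to carry over, so it supports no expected direction. Compound 3 is therefore expected to stay near the same limit, though a number cannot be ruled out. The expected change is a step that the limit leaves unreadable from compound 2 to compound 3. For compound 3 the estimated value is 12000 nM, with an expected range from 3000 nM to 40000 nM.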

Compound 3, half-maximal effective concentration: > 10000 nM
Compound 3: only a limit was reported; the forecaster's own chance of this, stated with the estimate: 80%; the middle value lies beyond the limit too.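

Compound 1, compound 2 and compound 3 each give only a limit, so no step among them can be read: the limit of > 10000 nM in this assay, at which 3 of the 3 values shown sit.

The compounds shown leave open whether changing the group on that oxygen alters the result in this assay at all.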